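Adding a Chloro Group to Compound 2

This account rests on a few compounds, and the source may have more. Where it says the series, first, only, none or still open, it means among the compounds named here.

Three analogues sharing one core have been measured in a functional assay on PC-3 cells (Homo sapiens); on this read-out higher numbers stand for weaker inhibition of growth and lower numbers for stronger inhibition of growth. Compound 1 `O=S(=O)(/C=C/c1ccccc1)Cc1ccc(Nc2ncnc3ccccc23)cc1` gives only a limit, > 100000 nM. Compound 2 `O=S(=O)(/C=C/c1ccc(F)cc1)Cc1ccc(Nc2ncnc3ccccc23)cc1` gives 1000 nM, the lowest of the two numbers available; compound 3 `O=S(=O)(/C=C/c1ccc(Cl)cc1)Cc1ccc(Nc2ncnc3ccccc23)cc1` gives 43000 nM, and the step of a 43-fold higher number from compound 2 to compound 3 (1.63 log units; beyond the scatter) is large. Compound 4 `O=S(=O)(/C=C/c1ccc(F)cc1Cl)Cc1ccc(Nc2ncnc3ccccc23)cc1` has not yet been measured. It differs from compound 2 by chloro in place of hydrogen on an aromatic carbon. The closest measured step is an at least 2.3-fold lower number from compound 1 to compound 3 (0.36 log units; beyond the scatter), which also placed chloro on this ring, though at a different carbon, while a 43-fold higher number from compound 2 to compound 3 (1.63 log units; beyond the scatter) shows that trading fluoro for chloro costs much. Since fluoro is kept here, only a modest step is expected for compound 4 in this assay, an estimated 2000 nM (range 500 nM to 10000 nM), meaning an expected 2.0-fold higher number from compound 2 to compound 4 (0.30 log units; within the scatter).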

Compound 4, concentration for 50% growth inhibition: 100000 nM
For compound 4 the middle estimate is 50-fold (1.70 log units) below the measured one; the whole stated range lies below it.
By their numbers in this assay, from the lowest: compound 2; then compound 3; then compound 4.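

In this assay, chloro in place of hydrogen on an aromatic carbon, ortho to a large group and meta to a fluoro group, brought a large loss of growth inhibition, a 100-fold higher number from compound 2 to compound 4 (2.00 log units; beyond the scatter). Compound 4 also sits on the weaker side of the 4-chlorophenyl analogue, a 2.3-fold higher number from compound 3 to compound 4 (0.37 log units; beyond the scatter). Chloro on this ring therefore does not read the same way across the series: the same change on two cores in this assay, an at least 2.3-fold lower number (0.36 log units; beyond the scatter) from compound 1 to compound 3 and a 100-fold higher number (2.00 log units; beyond the scatter) from compound 2 to compound 4, at least 230-fold (2.36 log units) apart, beyond the scatter of two such steps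

The remaining step, a number no higher from compound 1 to compound 4 (the limit leaves the size open), cannot be read, since the value of compound 1 is a limit. As far as these compounds go, whether a methyl or a methoxy group on this same carbon would bring the same loss remains open.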